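Series notes: one chloro removed from compound 3

This account rests on a few compounds, and the source may have more. Where it says the series, first, only, none or still open, it means among the compounds named here.

Measured in a functional assay on PC-3 cells (Homo sapiens) for inhibition, read by sulforhodamine B assay, with a stated time of 48 h; on this read-out lower numbers stand for stronger inhibition of growth and higher numbers for weaker inhibition of growth:
compound 1 `CN1CCN(CCCOc2cccc3nc(Nc4ccc(Cl)c(C(F)(F)F)c4)ccc23)CC1` gives 1570 nM
compound 2 `CC(C)c1ccc(Nc2ccc3c(OCCCN4CCN(C)CC4)cccc3n2)cc1` gives 12900 nM
compound 3 `CN1CCN(CCCOc2cccc3nc(Nc4cc(Cl)cc(Cl)c4)ccc23)CC1` gives 1760 nM

Compound 3 stands second highest of the three numbers. Its number and that of compound 1 lie within the scatter of each other (a 1.1-fold higher number from compound 1 to compound 3 (0.05 log units; within the scatter)), whereas compound 2 stands clearly apart (a 7.3-fold lower number from compound 2 to compound 3 (0.87 log units; beyond the scatter)). Compound 4 `CN1CCN(CCCOc2cccc3nc(Nc4cccc(Cl)c4)ccc23)CC1` differs from compound 3 by hydrogen in place of chloro on an aromatic carbon. Going by the values given here, no measured step removes a single substituent from the aryl group; the steps at hand exchange the whole group, and there an 8.2-fold higher number from compound 1 to compound 2 (0.91 log units; beyond the scatter) was the only change of real size, while a 1.1-fold higher number from compound 1 to compound 3 (0.05 log units; within the scatter) stayed flat. Loss of one chloro is expected to cost a little, a 1.7-fold higher number from compound 3 to compound 4 (0.23 log units; within the scatter). Compound 4 is estimated at 3000 nM, within 1200 nM to 8000 nM.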

Compound 4, concentration for 50% growth inhibition: 1810 nM
Compound 4: middle estimate off by 1.7-fold (0.22 log units), on the high side; measured number inside the range.
By their numbers in this assay, from the lowest: compounds 1, 3 and 4 (each within the scatter of the next); then compound 2.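

In this assay, going by these compounds alone, the loss of one chloro, the first single-substituent step, leaves the number flat (a 1.0-fold higher number from compound 3 to compound 4 (0.01 log units; within the scatter)). The 3-chlorophenyl group also sits level with the 4-chloro-3-(trifluoromethyl)phenyl group (a 1.2-fold higher number from compound 1 to compound 4 (0.06 log units; within the scatter)) and stays clearly apart from the 4-isopropylphenyl group (a 7.1-fold lower number from compound 2 to compound 4 (0.85 log units; beyond the scatter)), so the second chloro of the 3,5-dichlorophenyl group adds nothing measurable here. No evidence bears on this result.

From the compounds shown here alone, whether the remaining chloro can also go, leaving an unsubstituted phenyl, stays open, as does the outcome with a fluoro or a methoxy in its place.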